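The source may hold more compounds than are shown below. What is called first, only, known or untested is meant among the compounds shown, and "the series" means these compounds.

Measured so far:
- compound 1 `COc1cc2ncnc(NNC(=S)NC(=O)c3ccc(C(F)(F)F)cc3)c2cc1OC`, which in a functional assay on CNE-2 cells (Homo sapiens) for cytotoxicity, read by MTT assay, with a stated time of 72 h (a higher number here means a weaker inhibitor, a lower number a stronger inhibitor), gives 16500 nM
- compound 2 `O=C(NC(=S)NNc1ncnc2ccccc12)c1ccc(C(F)(F)F)cc1`, which in this assay gives 22500 nM

Among the measured compounds shown here, only two compounds have a number, and both sit within the usual scatter of each other. Compound 1 has the smaller of the two numbers, but that gap is too small to say that one compound inhibits the cells more strongly than the other. Both share the same core and the same 4-(trifluoromethyl)phenyl on the carbonyl carbon; they differ only in the two methoxy groups on the core of compound 1.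

Compound 3 `COc1cc2ncnc(NNC(=S)NC(=O)c3ccccc3OC)c2cc1OC` has not yet been measured in this assay. It keeps the core of compound 1 and changes the group on the carbonyl carbon: 2-methoxyphenyl in place of 4-(trifluoromethyl)phenyl on a carbonyl carbon. For the measured compounds named here, no measured pair shows this change, so its effect is unknown. With nothing to point either way, the step from compound 1 to compound 3 is expected to be small, within the scatter or close to it. Compound 3 is therefore estimated at 20000 nM, with a range from 6000 nM to 60000 nM, which means an expected step of a 1.2-fold higher number from compound 1 to compound 3 (0.08 log units; within the scatter).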

Compound 3, half-maximal inhibitory concentration: 8410 nM
For compound 3 the middle estimate is 2.4-fold (0.38 log units) above the measured one; measured number inside the range.
By their numbers in this assay, from the lowest: compounds 3, 1 and 2 (each within the scatter of the next, the first and the last beyond it).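

Among the compounds shown here, the change from 4-(trifluoromethyl)phenyl to 2-methoxyphenyl on a carbonyl carbon gives a 2.0-fold lower number from compound 1 to compound 3 (0.29 log units; within the scatter) in this assay and is the first step read at this position. The two groups differ in their atoms, and 2-methoxyphenyl brings a hydrogen-bond acceptor that 4-(trifluoromethyl)phenyl lacks, yet this step stays within the usual scatter, so this single pair does not separate the two groups. No measurement is at hand that could explain this reading.

From the compounds shown here alone, whether an amine, a carboxylic acid or a longer chain in this place would give a step beyond the scatter remains open. Going by these compounds, it is also open whether 2-methoxyphenyl would give a similar step on the core of compound 2, which lacks the two methoxy groups of compound 1.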